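The source may report more compounds than this note shows. Statements on the series, on what has been measured and on what is new or still open speak of the compounds shown alone.

Compound 1 `CN(N=O)C(=O)NC[C@H]1O[C@@H](n2ccc(=O)[nH]c2=O)[C@H](O)[C@@H]1O`: > 50 uM
Compound 2 `CN(N=O)C(=O)NC[C@H]1O[C@@H](n2cnc3c(N)ncnc32)[C@H](O)[C@@H]1O`: 40 uM

In a functional assay on HEp-2 cells (Homo sapiens) for cytotoxicity (a higher number here means that more compound is needed for the effect, a lower number that less compound is needed), compound 1 gives > 50 uM, which is a limit of the assay and not a number. Compound 2 gives 40 uM, the only number shown. For the measured compounds named here, compound 2 thus stands as the one measured value, with the other entry being (the limit of > 50 uM in this assay, at which 1 of the 2 values shown sits). Compound 3 `CNC(=O)NC[C@H]1O[C@@H](n2cnc3c(N)ncnc32)[C@H](O)[C@@H]1O` differs from compound 2 by a hydrogen atom in place of a group of 2 heavy atoms (1 nitrogen, 1 oxygen; no ring), on an amide-type nitrogen. Going by the values given here, no measured step shows what such a change does here. The expected step of a 2.0-fold higher number from compound 2 to compound 3 (0.30 log units; within the scatter) points toward more compound being needed, beyond the scatter. Compound 3 is expected near 80 uM, between 30 uM and 200 uM.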

Compound 3, concentration for half-maximal effect: > 60 uM
Compound 3 was reported as a limit; the forecaster's own chance of this, stated with the estimate: 70%; the middle value does not contradict the limit.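

In this assay, for the compounds shown here, a hydrogen atom in place of the group of 2 heavy atoms (1 nitrogen, 1 oxygen), on the amide-type nitrogen, gives an at least 1.5-fold higher number from compound 2 to compound 3 (0.17 log units; that floor lies within the scatter) as the first direct reading of this change. That reading alone does not establish a shift beyond the scatter. The true size of the step stays unknown because compound 3 sits at a limit of the assay and not at a number: the limit of > 60 uM in this assay, at which 1 of the 3 values shown sits.

Open, as far as these compounds go, is what a longer chain or an amine on this nitrogen would do. Also open, from the compounds shown here alone, is whether the same change behaves alike on the core of compound 1.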